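Three limits, then a dichlorophenyl swap

The source may hold more compounds than are shown below. What is called first, only, known or untested is meant among the compounds shown, and "the series" means these compounds.

Compound 1 (`COc1ccc(C(=O)/C=C/c2cccc(F)c2)c2c1C=CC(C)(C)O2`), compound 2 (`COc1ccc(C(=O)/C=C/c2ccc(Cl)cc2)c2c1C=CC(C)(C)O2`) and compound 3 (`COc1ccc(C(=O)/C=C/c2cccs2)c2c1C=CC(C)(C)O2`) share one core and differ only in the group on a double-bonded chain carbon. All three were tested in a functional assay on SK-OV-3 cells (Homo sapiens) for antiproliferative activity, read by MTT assay, with a stated time of 24 h; on this read-out higher numbers stand for weaker inhibition and lower numbers for stronger inhibition. Compound 1 gives > 10000 nM, which is a limit and not a number. Compound 2 gives > 10000 nM, also a limit. Compound 3 gives > 10000 nM, again a limit. Compound 3 therefore stands with the others, at the limit of > 10000 nM in this assay, at which 3 of the 3 values shown sit.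

Compound 4 (`COc1ccc(C(=O)/C=C/c2ccc(Cl)c(Cl)c2)c2c1C=CC(C)(C)O2`) carries 3,4-dichlorophenyl in place of thiophen-2-yl on a double-bonded chain carbon bound to a double-bonded chain carbon. Among the measured compounds shown here, three measured steps bear on this change: a step that the two limits leave unreadable from compound 1 to compound 2, a step that the two limits leave unreadable from compound 1 to compound 3 and a step that the two limits leave unreadable from compound 2 to compound 3. None has a readable size, so none gives a direction, and no step beyond the scatter is expected in this assay. The expected change is a step that the limit leaves unreadable from compound 3 to compound 4. For compound 4 the estimated half-maximal inhibitory concentration is 12000 nM, with an expected range from 4000 nM to 30000 nM.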

Compound 4, half-maximal inhibitory concentration: 9940 nM
The estimate for compound 4 lay 1.2-fold (0.08 log units) above the measured number; the range from low to high includes it.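

Among the compounds shown, compound 4 is the only one that gives a true number in this assay, 9940 nM. With 3,4-dichlorophenyl in place of thiophen-2-yl, the data show a number no higher from compound 3 to compound 4 (the limit leaves the size open). With chloro in place of hydrogen on an aromatic carbon, they show a number no higher from compound 2 to compound 4 (the limit leaves the size open). With 3,4-dichlorophenyl in place of 3-fluorophenyl, they show a number no higher from compound 1 to compound 4 (the limit leaves the size open). The other compounds remain limits, not numbers: the limit of > 10000 nM in this assay, at which 3 of the 4 values shown sit. The steps to compound 4 from compound 1, compound 2 and compound 3 all start from a limit and cannot be read, and this includes the change of chloro in place of hydrogen on an aromatic carbon.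

From the compounds shown here alone, how far compound 4 really lies from its neighbours therefore stays open. Going by these compounds, it is also open how this assay would respond to a group such as an amine or a carboxylic acid on the aromatic ring of the 3,4-dichlorophenyl group.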